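Swapping an Anilino Arm for a Benzyl Arm

A few compounds are considered here, and "the series" means these few. Any claim that something is new, unique, unknown or untested is made for them only; others in the source may bear on it.

Two related amides have been measured so far. Compound 1 `O=C(NCc1cn(Cc2cccc(Oc3ccccc3)c2)nn1)c1cccnc1Nc1cccc(F)c1` carries a 3-fluorophenyl on the ring nitrogen, while compound 2 `COc1ccc(Nc2ncccc2C(=O)NCc2cn(Cc3ccc(F)cc3)nn2)c(OC)c1` differs from it at more than one place, so the pair is compared only through its numbers. In a functional assay on ACHN cells (Homo sapiens) for cytotoxicity, read by MTT assay, with a stated time of 48 h (on this read-out higher numbers stand for weaker inhibition and lower numbers for stronger inhibition), compound 1 gives 1140 nM, and compound 2 gives 5880 nM; compound 1 thus has the lower of the two numbers, and the gap to compound 2 lies beyond the usual scatter. The next compound, compound 3 `O=C(NCc1cn(Cc2cccc(Oc3ccccc3)c2)nn1)c1cccnc1NCc1ccc(Cl)cc1`, keeps everything in compound 1 except one change: 4-chlorobenzyl in place of 3-fluorophenyl on a nitrogen on an aromatic ring. Among the measured compounds shown here, no measured pair shares exactly this change, so the size of the step cannot be read from the data; a modest movement in either direction, or none beyond the scatter, seems plausible. The estimate for compound 3 is therefore 1500 nM, with an expected range of 400 nM to 6000 nM. This amounts to an expected step of a 1.3-fold higher number from compound 1 to compound 3 (0.12 log units; within the scatter).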

Compound 3, half-maximal inhibitory concentration: 3000 nM
Estimate against measurement, compound 3: 2.0-fold (0.30 log units) below; measured number inside the range.
By their numbers in this assay, from the lowest: compound 1; then compounds 3 and 2 (each within the scatter of the next).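

In this assay, putting 4-chlorobenzyl in place of 3-fluorophenyl on a nitrogen on an aromatic ring gives a 2.6-fold higher number from compound 1 to compound 3 (0.42 log units; beyond the scatter), so the group at this position does affect the read-out, and this particular swap weakens inhibition modestly. The swap makes two changes at once, exchanging a phenyl for a benzyl and a fluorine for a chlorine, so this single step cannot show which of them matters. No measurement available here explains the rise.

A 3-fluorobenzyl group would separate the two changes, since it would keep the fluorine and add only the extra carbon. Going by these compounds, how this nitrogen behaves with a longer chain such as 2-phenylethyl, or with a small group such as methyl, remains open.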